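Swapping Fluoro for Methoxy on the Aryl Triazole

This account rests on a few compounds, and the source may have more. Where it says the series, first, only, none or still open, it means among the compounds named here.

The three measured compounds share one core and differ only in the aromatic ring attached to the triazole nitrogen. In a functional assay on LoVo cells (Homo sapiens) for inhibition, read by MTT assay, with a stated time of 24 h (a higher number here means a weaker inhibitor, a lower number a stronger inhibitor), compound 1 `CC1(C)[C@H]2CC[C@]1(C)N(Cc1cn(-c3cccc(F)c3)nn1)C(=O)C2` gives 90 nM, the lowest of the three numbers. Compound 2 `CC1(C)[C@H]2CC[C@]1(C)N(Cc1cn(-c3cccc(O)c3)nn1)C(=O)C2` gives 410 nM, and compound 3 `CC1(C)[C@H]2CC[C@]1(C)N(Cc1cn(-c3ccc(Cl)cc3)nn1)C(=O)C2` gives 160 nM. The step of a 4.6-fold higher number from compound 1 to compound 2 (0.66 log units; beyond the scatter) is the only one beyond the scatter that starts from compound 1; the step of a 1.8-fold higher number from compound 1 to compound 3 (0.25 log units; within the scatter) stays within it.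

Compound 4 `COc1cccc(-n2cc(CN3C(=O)C[C@@H]4CC[C@@]3(C)C4(C)C)nn2)c1` has not yet been measured. It differs from compound 1 in one place: methoxy in place of fluoro on an aromatic carbon. The closest measured guide is the change from compound 1 to compound 2, where an oxygen-bearing group took the place of the fluoro at the same carbon and the number rose by a 4.6-fold higher number from compound 1 to compound 2 (0.66 log units; beyond the scatter). For the measured compounds named here, the methoxy in compound 4 also carries an oxygen but, as counted above, brings no hydrogen-bond donor, so the same size of shift cannot simply be assumed; no measured pair shows a methoxy at all. The step is therefore expected to be a 2.2-fold higher number from compound 1 to compound 4 (0.35 log units; beyond the scatter), smaller than the hydroxy step. Compound 4 is expected to give about 200 nM in this assay, most likely between 80 nM and 500 nM.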

Compound 4, half-maximal inhibitory concentration: 80 nM
For compound 4 the middle estimate is 2.5-fold (0.40 log units) above the measured one; the measured number falls inside the stated range.
By their numbers in this assay, from the lowest: compounds 4, 1 and 3 (each within the scatter of the next); then compound 2.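

At this position on the aryl ring, methoxy and fluoro cannot be told apart in this assay: the result is a 1.1-fold lower number from compound 1 to compound 4 (0.05 log units; within the scatter) so an oxygen on this carbon does not by itself bring the higher number seen with compound 2. For the compounds shown here, the step of a 5.1-fold lower number from compound 2 to compound 4 (0.71 log units; beyond the scatter) lies beyond the scatter, and since the only change is methyl in place of the hydrogen on the oxygen, the higher number of compound 2 goes with the free hydroxy rather than with the oxygen, at least in this single pair. The comparison a 2.0-fold lower number from compound 3 to compound 4 (0.30 log units; within the scatter) also stays within the scatter, so the 3-methoxyphenyl and 4-chlorophenyl compounds cannot be ranked against each other, and no measurement shown here explains any of these steps.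

As far as these compounds go, it remains open whether a longer chain on the oxygen, such as ethoxy, would stay level with methoxy or move towards the number of compound 2. From the compounds shown here alone, it is equally open how an amine or a carboxylic acid on the same aromatic carbon would behave, since these compounds cover only a small set of groups on this ring.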